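Swapping fluoro for methoxy on the benzyl ring

The compounds below may be only part of what the source reports. "The series", "measured", "known", "first", "only" and "open" are said of these compounds alone.

Measured compounds:
compound 1 `COc1ccc2c(=O)c(/C=C/C(=O)NCc3cccc(F)c3)coc2c1`: 475000 nM
compound 2 `COc1ccc2c(=O)c(/C=C/C(=O)NCc3ccc(F)cc3)coc2c1`: 133000 nM

In an ADME assay on HepG2 2.2.15 cells (Homo sapiens) for cytotoxicity, read by MTT assay, with stated times of 48 h and 9 days (on this read-out higher numbers stand for lower toxicity in this test and lower numbers for higher toxicity in this test), compound 2 gives 133000 nM, the lowest of the two numbers shown; its nearest neighbour is compound 1 with 475000 nM. For the measured compounds named here, the only step between measured compounds is a 3.6-fold lower number from compound 1 to compound 2 (0.55 log units; beyond the scatter), a change in where the fluoro sits on the ring. Compound 3 `COc1ccc(CNC(=O)/C=C/c2coc3cc(OC)ccc3c2=O)cc1` differs from compound 2 by methoxy in place of fluoro on an aromatic carbon. Going by the values given here, no measured step exchanges fluoro for methoxy, so this change is untested here; the one known step is modest and concerns a different kind of change, so it gives only a weak hint of how sensitive this assay is to the benzyl substituent. Compound 3 is therefore expected to stay close to compound 2, a 1.5-fold higher number from compound 2 to compound 3 (0.18 log units; within the scatter), not clearly beyond the scatter. The estimate for compound 3 is 200000 nM, with a range from 70000 nM to 600000 nM.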

Compound 3, half-maximal cytotoxic concentration: 43000 nM
Compound 3: middle estimate off by 4.7-fold (0.67 log units), on the high side; measured number below the stated range.
By their numbers in this assay, from the lowest: compound 3; then compound 2; then compound 1.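

In this assay, the identity of the group para to a large group matters, not only where a fluoro sits on the ring: methoxy in place of fluoro gives a modest step beyond the scatter (a 3.1-fold lower number from compound 2 to compound 3 (0.49 log units; beyond the scatter)). Against the 3-fluorophenyl of compound 1, the 4-methoxyphenyl gives a large step (an 11-fold lower number from compound 1 to compound 3 (1.04 log units; beyond the scatter)), which leaves compound 3 with the lowest number of the three and so the highest toxicity in this test. No measurement shown here explains why the number falls with this change.

The compounds shown leave open whether other groups at this place, such as an amine, a carboxylic acid or a longer ethoxy chain, would lower the number further or raise it. They also leave open whether methoxy would give a similar step where the fluoro of compound 1 sits.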